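The source may hold more compounds than are shown below. What is called first, only, known or untested is meant among the compounds shown, and "the series" means these compounds.

Compound 2 `COc1ncc(-c2ccc3nc(NC(=O)NC4CC4)nn3c2)cc1NS(=O)(=O)c1ccc(F)cc1` is the reference point. In a functional assay on U-87MG ATCC cells for cytotoxicity against U-87 MG (Homo sapiens), read by MTT assay, with a stated time of 72 h (a higher number here means a weaker inhibitor, a lower number a stronger inhibitor), compound 2 gives 540 nM, the lowest of the three numbers in hand. Compound 3 `CCN(CC)CCNC(=O)Nc1nc2ccc(-c3cnc(OC)c(NS(=O)(=O)c4ccc(F)cc4F)c3)cn2n1` gives 1060 nM, which sits within the scatter of compound 2, so no order between them can be claimed. Among the measured compounds shown here, compound 1 `COc1ncc(-c2ccc3nc(NC(=O)N4CCCC4)nn3c2)cc1NS(=O)(=O)c1ccc(F)cc1` gives 1690 nM, and the only single-point step measured, a 3.1-fold lower number from compound 1 to compound 2 (0.50 log units; beyond the scatter), replaced pyrrolidin-1-yl with cyclopropylamino on the carbonyl carbon. Compound 4 `COc1ncc(-c2ccc3nc(NC(=O)NCCN(C)C)nn3c2)cc1NS(=O)(=O)c1ccc(F)cc1` carries the change (2-(dimethylamino)ethyl in place of cyclopropyl on an amide-type nitrogen). That step bears no measured twin; the closest hint is compound 3, whose urea also ends in a dialkylaminoethyl chain and whose value lies within the scatter of compound 2. Compound 4 is therefore expected to show a 1.6-fold higher number from compound 2 to compound 4 (0.20 log units; within the scatter), that is, no step beyond the scatter. The estimate for compound 4 in this assay is 850 nM, with a range from 350 nM to 2100 nM.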

Compound 4, half-maximal inhibitory concentration: 980 nM
For compound 4 the middle estimate is 1.2-fold (0.06 log units) below the measured one; the measured number falls inside the stated range.
By their numbers in this assay, from the lowest: compounds 2, 4, 3 and 1 (each within the scatter of the next, the first and the last beyond it).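

On the amide-type nitrogen in this assay, 2-(dimethylamino)ethyl in place of cyclopropyl gives a 1.8-fold higher number from compound 2 to compound 4 (0.26 log units; within the scatter) and so an open chain ending in an amine holds level with the small carbon ring at this place. Set against the pyrrolidin-1-yl group, the same chain gives a 1.7-fold lower number from compound 1 to compound 4 (0.24 log units; within the scatter) and so it cannot be told apart from that group either. Nothing available bears on why these values fall as they do. Still open, as far as these compounds go, is whether a longer chain, a morpholine at the chain end or a primary amine would move the number beyond the scatter from compound 2.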